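The source may hold more compounds than are shown below. What is called first, only, known or untested is meant among the compounds shown, and "the series" means these compounds.

Measured compounds:
Compound 1 `Cn1c(/C=C2\SC(=O)N(CC(=O)Nc3cc(C(C)(C)C)on3)C2=O)nc2ccccc21` — in a functional assay on PC-3 cells (Homo sapiens) for inhibition, read by MTT assay, with a stated time of 48 h (on this read-out higher numbers stand for weaker inhibition and lower numbers for stronger inhibition), compound 1 gives only a limit, > 50000 nM.
Compound 2 `Cn1c(/C=C2\SC(=O)N(CC(=O)N3CCCCC3)C2=O)nc2ccccc21` — in this assay compound 2 gives only a limit, > 50000 nM.
Compound 3 `Cn1c(/C=C2\SC(=O)N(CC(=O)N3CCCC3)C2=O)nc2ccccc21` — in this assay compound 3 gives only a limit, > 50000 nM.

Compound 2 therefore stands at the ceiling of the numbers shown, together with the other two values, as summarised by the limit of > 50000 nM in this assay, at which 3 of the 3 values shown sit. The steps a step that the two limits leave unreadable from compound 1 to compound 2, a step that the two limits leave unreadable from compound 1 to compound 3 and a step that the two limits leave unreadable from compound 2 to compound 3 cannot be sized, since every end point sits at the limit of > 50000 nM in this assay, at which 3 of the 3 values shown sit.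

Compound 4 `CC(C)n1c(/C=C2\SC(=O)N(CC(=O)N3CCCCC3)C2=O)nc2ccccc21` differs from compound 2 by isopropyl in place of methyl on an aromatic nitrogen. Going by the values given here, none of the measured steps varies this position; all of them alter the amide substituent, and none is readable. Among the compounds with values here, no measured step bears on the change, so no shift beyond the scatter is expected in this assay.

Compound 4 is estimated at 50000 nM, with a range of 15000 nM to 150000 nM, most likely again reported only as a limit. The expected step of a number no higher from compound 2 to compound 4 (the limit leaves the size open) is accordingly nil.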

Compound 4, half-maximal inhibitory concentration: > 50000 nM
Compound 4: a limit, no number; the forecaster's own chance of this, stated with the estimate: 85%; the middle value sits exactly at the limit.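

No step can be read between compound 2 and compound 4, since both end points are limits: the limit of > 50000 nM in this assay, at which 4 of the 4 values shown sit.

Left open is where any of the four compounds lies beyond that limit, and whether isopropyl in place of methyl on the aromatic nitrogen changes inhibition at all.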